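Removing a Nitro Group from a Thiazole-Type Scaffold

The source may hold more compounds than are shown below. What is called first, only, known or untested is meant among the compounds shown, and "the series" means these compounds.

Three small compounds built on a related sulfur- and nitrogen-containing five-membered core were tested in an ADME assay on L02 cells (Homo sapiens) for inhibition, read by MTT assay, with a stated time of 48 h, tested at 100 uM; a lower number here means less inhibition, a higher number more inhibition at the concentration tested (going by the name of the read-out). Compound 1 `Cc1ccccc1-c1nc(=O)ss1` gives 18.6% in this assay, while compound 2 `O=c1oc(-c2cc(F)c(Cl)nc2Cl)ns1` gives 15.1%. Compound 3 `O=c1nc(-c2ccc([N+](=O)[O-])cc2Cl)ss1` gives 28.6%, the top number of the three; compound 1 lies within the usual scatter of it, so the two cannot be told apart, whereas compound 2 lies beyond the scatter.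

Compound 4 `O=c1nc(-c2ccccc2Cl)ss1` has not yet been measured in this assay. It differs from compound 3 in one place: hydrogen in place of nitro on an aromatic carbon. Within the data shown here, with no measured pair showing the effect of this kind of change, the only guide is that compound 3 and compound 1, which also lack a nitro group, sit within the scatter of each other in this assay. A small downward step, not beyond the scatter, is therefore expected from compound 3 to compound 4, namely a number 8.6 percentage points lower from compound 3 to compound 4 (within the scatter). Compound 4 is estimated to give 20% in this assay, within a range from 8% to 32%.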

Compound 4, a percentage reported as inhibition, at one concentration (the size of the read-out at that concentration, not a potency): 40.1%
The estimate for compound 4 lay 20.1 percentage points below the measured number; the whole stated range lies below it.
By their numbers in this assay, from the lowest: compounds 2, 1 and 3 (each within the scatter of the next, the first and the last beyond it); then compound 4.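

Replacing the nitro group on the aromatic carbon meta to the chloro group with hydrogen gives a number 11.5 percentage points higher from compound 3 to compound 4 (beyond the scatter) in this assay and so shows that this nitro group is not needed for inhibition at the concentration tested. The change of chloro in place of methyl on an aromatic carbon gives a number 21.5 percentage points higher from compound 1 to compound 4 (beyond the scatter) and shows, in a first one-place comparison among these compounds, that this other aromatic position also matters in this assay. Nothing available explains either step.

On these data alone, whether an amine, a carboxylic acid or a methoxy group on the carbon that held the nitro group would give a higher or lower number remains open. So does whether the step from nitro to hydrogen would look the same with methyl in place of chloro.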